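The compounds below may be only part of what the source reports. "The series", "measured", "known", "first", "only" and "open" are said of these compounds alone.

The measured compounds:
Compound 1, `Cn1cc(-c2cc(C(C)(C)O)ccc2OC2CC2)c2cc(C(=O)NCCCCCCC(=O)NO)[nH]c2c1=O`, in an assay on isolated protein for inhibition of protein deacetylase HDAC6 (Homo sapiens), read by fluorescence (on this read-out lower numbers stand for stronger inhibition and higher numbers for weaker inhibition), gives 5.5 nM.
Compound 2, `Cn1cc(-c2ccccc2Oc2ccccc2)c2cc(C(=O)NCc3ccc(C(=O)Nc4ccccc4N)cc3)[nH]c2c1=O`, in this assay gives > 500 nM.

Compound 2 stands at the weak end of what has been measured. The value reported for compound 2 in this assay is a limit of the assay, not a number: it sits at the limit of > 500 nM in this assay, at which 1 of the 2 values shown sits. Compound 1 in this assay gives 5.5 nM, a number rather than a limit, and it shows that the shared core can reach strong inhibition in this assay.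

Compound 3, `Cn1cc(-c2ccccc2Oc2ccccc2)c2cc(C(=O)NCc3ccc(C(=O)NO)cc3)[nH]c2c1=O`, has not yet been measured. It differs from compound 2 in one place: hydroxy in place of 2-aminophenyl on an amide-type nitrogen. Put another way, the (2-aminophenyl)carbamoyl group of compound 2 becomes a hydroxycarbamoyl group in compound 3. Among the measured compounds shown here, no measured step of this kind is available, so the size of the change in this assay is a matter of expectation only. The step from compound 2 to compound 3 is expected to be large and towards stronger inhibition, well beyond the scatter, an expected at least 41-fold lower number from compound 2 to compound 3 (1.61 log units; beyond the scatter). For compound 3 in this assay the estimate is 12 nM, expected to fall between 2.5 nM and 60 nM.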

Compound 3, half-maximal inhibitory concentration: 15.3 nM
Compound 3: middle estimate off by 1.3-fold (0.11 log units), on the low side; low and high end bracket the measured number.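

In this assay, the group on this amide-type nitrogen is the only difference, and hydroxy in place of 2-aminophenyl gives an at least 32-fold lower number from compound 2 to compound 3 (1.51 log units; beyond the scatter). Compound 2 carries a limit of the assay, not a number: the limit of > 500 nM in this assay, at which 1 of the 3 values shown sits. The printed step is therefore a floor rather than a full measure, and it arises although a six-membered aromatic ring of carbon leaves while the counts of hydrogen-bond donors and acceptors stay the same, so those counts do not separate the two groups.

The compounds shown hold only these two groups on this nitrogen, so it remains open whether a methoxy group or a plain amine there, or a carboxylic acid in place of the whole hydroxycarbamoyl group, would keep inhibition at the level of compound 3. Also open, from the compounds shown here alone, is whether 2-aminophenyl in place of hydroxy on compound 1 would produce a step of similar size, since that compound differs from compound 3 in more than one place and the pair cannot be read as a single change.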